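Propanoyl to vinylcarbonyl on the piperidine series

This account rests on a few compounds, and the source may have more. Where it says the series, first, only, none or still open, it means among the compounds named here.

Values in an ADME assay on BaF3 cells (Mus musculus) for antiproliferative activity; a lower number here means a stronger inhibitor of growth, a higher number a weaker inhibitor of growth:
- compound 1 `Cc1ccc(NC(=O)c2cccc(C(F)(F)F)c2)cc1OCCNC(=O)c1ccno1`: > 10000 nM, a limit
- compound 2 `Cc1ccc(NC(=O)c2cccc(C(F)(F)F)c2)cc1OC1CCN(C(=O)c2ccncc2)CC1`: > 10000 nM, a limit
- compound 3 `CCC(=O)N1CCC(Oc2cc(NC(=O)c3cccc(C(F)(F)F)c3)ccc2C)CC1`: > 10000 nM, a limit
- compound 4 `C=CC(=O)N1CCC(Oc2cc(NC(=O)c3cccc(C(F)(F)F)c3)ccc2C)CC1`: not yet measured

Compound 3 stands at > 10000 nM, which is a limit and not a number. Going by the values given here, the series so far gives no number at all, only (the limit of > 10000 nM in this assay, at which 3 of the 3 values shown sit).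

The next change is vinyl in place of ethyl on a carbonyl carbon, with propanoyl becoming vinylcarbonyl: vinyl in place of ethyl on a carbonyl carbon. The rest of the structure stays as it is in compound 3.

Among the compounds with values here, two measured steps bear on this change: a step that the two limits leave unreadable from compound 2 to compound 3, at the same carbonyl carbon, and a step that the two limits leave unreadable from compound 1 to compound 3, on the oxygen. Within the data shown here, neither has a readable size, so neither sets an expected size for this step, and no measured compound carries vinyl. The expectation in this assay is therefore loose. Compound 4 may well remain at the limit, and any number it does give would have to fall on the stronger side of that limit. The expected step, an at least 2.0-fold lower number from compound 3 to compound 4 (0.30 log units; that floor lies within the scatter), is an estimate that leans toward stronger growth inhibition and is held with little confidence. Compound 4 is estimated at 5000 nM, with an expected range of 500 nM to 15000 nM.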

Compound 4, concentration for 50% growth inhibition: > 10000 nM
Compound 4 ended at the assay's limit; the forecaster's own chance of this, stated with the estimate: 50%; at least 2.0-fold (0.30 log units) between middle value and limit.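

In this assay compound 4 gives > 10000 nM, which is a limit and not a number. No step from compound 1, compound 2 or compound 3 to compound 4 can be read, since all the values are limits: the limit of > 10000 nM in this assay, at which 4 of the 4 values shown sit.

The compounds shown leave open how vinyl and ethyl on the carbonyl carbon compare in this assay, and whether any compound in this series gives a readable number there.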